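A side-chain swap and expected cell toxicity

This account rests on a few compounds, and the source may have more. Where it says the series, first, only, none or still open, it means among the compounds named here.

Compound 2, `COC(=O)[C@@H](NC(=O)CCC(=O)Oc1ccc(C[C@H]2C(=O)OC[C@@H]2Cc2ccc(OC)c(OC)c2)cc1OC)C(C)C`, was tested in an ADME assay on HeLa cells (Homo sapiens) for cytotoxicity, read by MTT assay (a higher number here means a weaker inhibitor, a lower number a stronger inhibitor), where compound 2 gives 64000 nM. Of the two measured compounds, compound 2 has the lowest number. Compound 1, `COc1ccc(C[C@H]2COC(=O)[C@@H]2Cc2ccc(OC(=O)CCC(=O)N3CCCC3)c(OC)c2)cc1OC`, gives 201000 nM in this assay. Among the measured compounds shown here, the one measured step is a 3.1-fold lower number from compound 1 to compound 2 (0.50 log units; beyond the scatter), and it lies beyond the scatter. Compound 3, `COC(=O)[C@H](CCSC)NC(=O)CCC(=O)Oc1ccc(C[C@H]2C(=O)OC[C@@H]2Cc2ccc(OC)c(OC)c2)cc1OC`, has not yet been measured; it differs from compound 2 in one place: 2-(methylsulfanyl)ethyl in place of isopropyl on a saturated chain carbon bound to an amide-type nitrogen and a carbonyl carbon. For the measured compounds named here, the measured step put (1-(methoxycarbonyl)-2-methylpropyl)amino in place of pyrrolidin-1-yl, a change of the whole group on the carbonyl carbon, so it bears only loosely on the present swap of isopropyl for 2-(methylsulfanyl)ethyl, and no other measured step speaks to it. A step within the scatter in this assay is therefore expected: a 1.2-fold lower number from compound 2 to compound 3 (0.07 log units; within the scatter). Compound 3 is estimated at 55000 nM, with a range from 20000 nM to 160000 nM.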

Compound 3, half-maximal inhibitory concentration: 199000 nM
Compound 3: the middle estimate sits 3.6-fold (0.56 log units) below what was measured; measured number above the stated range.
By their numbers in this assay, from the lowest: compound 2; then compounds 3 and 1 (each within the scatter of the next).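

In this assay the side chain alone matters at this saturated chain carbon: with the rest of the molecule unchanged, the swap gives a 3.1-fold higher number from compound 2 to compound 3 (0.49 log units; beyond the scatter). This is sharper than the earlier step, which replaced the whole group on the carbonyl carbon. The second comparison gives a 1.0-fold lower number from compound 1 to compound 3 (0.00 log units; within the scatter), so the lower number of compound 2 does not come with every (1-(methoxycarbonyl)alkyl)amino group in place of pyrrolidin-1-yl; here it holds for the isopropyl version only, and compound 3 goes against any such pattern. No measurement at hand explains the step.

The compounds shown do not separate the effect of the sulfur from that of the longer chain, which an all-carbon butyl chain at this place could address. Going by these compounds, whether a carboxylic acid in place of the methyl ester would shift the number also remains open.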